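From Pyrazolyl Ring to Hydroxyethyl Chain on the Piperidine

The compounds below may be only part of what the source reports. "The series", "measured", "known", "first", "only" and "open" are said of these compounds alone.

Compound 3 `CCc1nn(CC)c(C2CCN(C(=O)CN3CN(c4ccccc4)C4(CCN(C(=O)c5ccc(C(C)(C)C)cc5)CC4)C3=O)CC2)c1C` gives 2500 nM in an assay on HEK293 cells for displacement of a labelled ligand from NPC1-like intracellular cholesterol transporter 1 (Homo sapiens) (a lower number here means a stronger inhibitor, a higher number a weaker inhibitor), the second highest of the three numbers measured. Compound 2 `CC1(C)CC(OC(=O)CN2CN(c3ccccc3)C3(CCN(C(=O)c4ccc(C(C)(C)C)cc4)CC3)C2=O)CC(C)(C)N1` gives 1300 nM and compound 1 `CC(C)(C)c1ccc(C(=O)N2CCC3(CC2)C(=O)N(CC(=O)NCCCCCNS(C)(=O)=O)CN3c2ccccc2)cc1` gives 5500 nM. Among the measured compounds shown here, the only step between compounds differing in one place, a 4.2-fold lower number from compound 1 to compound 2 (0.63 log units; beyond the scatter), changes the group on a carbonyl carbon and shows that altering this outer part of the shared core moves the number modestly. Compound 4 `CC(C)(C)c1ccc(C(=O)N2CCC3(CC2)C(=O)N(CC(=O)N2CCC(CCO)CC2)CN3c2ccccc2)cc1` differs from compound 3 by 2-hydroxyethyl in place of 1,3-diethyl-4-methyl-1H-pyrazol-5-yl on a saturated ring carbon. For the measured compounds named here, no measured step covers this exact change, so only a modest shift is anticipated. Compound 4 is expected to give 2000 nM, within a range from 700 nM to 6000 nM. This estimate corresponds to an expected step of a 1.3-fold lower number from compound 3 to compound 4 (0.10 log units; within the scatter).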

Compound 4, half-maximal inhibitory concentration: 2600 nM
Compound 4: middle estimate off by 1.3-fold (0.11 log units), on the low side, within the range that was stated.
By their numbers in this assay, from the lowest: compounds 2, 3 and 4 (each within the scatter of the next); then compound 1.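

In this assay, replacing the 1,3-diethyl-4-methyl-1H-pyrazol-5-yl, with 10 heavy atoms and a ring, by the 2-hydroxyethyl, with 3 heavy atoms and no ring, gives a 1.0-fold higher number from compound 3 to compound 4 (0.02 log units; within the scatter), so this large change at the saturated ring carbon leaves no readable difference. Across the whole group on the carbonyl carbon, the data give a 2.0-fold higher number from compound 2 to compound 4 (0.30 log units; within the scatter) and a 2.1-fold lower number from compound 1 to compound 4 (0.33 log units; beyond the scatter), so compound 4 is separated from compound 1 but not from compound 2. No evidence is given to explain these results. On these data alone, whether a 2-aminoethyl or a carboxymethyl group on the same ring carbon would give a different number remains open.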